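Trifluoromethyl for methyl on the anilide ring

This account rests on a few compounds, and the source may have more. Where it says the series, first, only, none or still open, it means among the compounds named here.

Three compounds of the series share one core and differ only on the anilide ring. Compound 1 `O=C(CN1CCC(c2cccc[n+]2[O-])CC1)Nc1ccc(F)cc1F` gives 103 nM in a functional assay on HEK293 cells for agonist activity at D(4) dopamine receptor (Homo sapiens), read by FLIPR; on this read-out higher numbers stand for an effect only at larger amounts of compound and lower numbers for an effect already at smaller amounts. Compound 2 `O=C(CN1CCC(c2cccc[n+]2[O-])CC1)Nc1ccc(F)cc1` gives 85 nM in this assay, and compound 3 `Cc1cc(F)ccc1NC(=O)CN1CCC(c2cccc[n+]2[O-])CC1` gives 60 nM in this assay. Compound 3 holds the lowest of the three numbers, yet the steps that reach it, a 1.7-fold lower number from compound 1 to compound 3 (0.23 log units; within the scatter) and a 1.4-fold lower number from compound 2 to compound 3 (0.15 log units; within the scatter), both stay within the scatter, as does a 1.2-fold lower number from compound 1 to compound 2 (0.08 log units; within the scatter); on the numbers shown the three compounds cannot be told apart.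

Compound 4 `O=C(CN1CCC(c2cccc[n+]2[O-])CC1)Nc1ccc(F)cc1C(F)(F)F` is not yet measured. It differs from compound 3 by trifluoromethyl in place of methyl on an aromatic carbon. Every measured step at that carbon, fluoro to hydrogen, fluoro to methyl, hydrogen to methyl, left this assay unchanged beyond the scatter, so the measured record gives no reason to expect a step of any size from a further exchange at the same carbon. A trifluoromethyl group has, however, not been tried anywhere in the series, so the range must stay wide.

Compound 4 is therefore expected near 75 nM in this assay, with a range from 30 nM to 200 nM, meaning an estimated step of a 1.3-fold higher number from compound 3 to compound 4 (0.10 log units; within the scatter).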

Compound 4, half-maximal effective concentration: 473 nM
Estimate against measurement, compound 4: 6.3-fold (0.80 log units) below; measured number above the stated range.
By their numbers in this assay, from the lowest: compounds 3, 2 and 1 (each within the scatter of the next); then compound 4.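

In this assay, within the data shown here, hydrogen, fluoro and methyl on this aromatic carbon, ortho to a large group, gave numbers within the scatter of each other, and trifluoromethyl is the first group to leave that cluster, with a 7.9-fold higher number from compound 3 to compound 4 (0.90 log units; beyond the scatter), a 5.6-fold higher number from compound 2 to compound 4 (0.75 log units; beyond the scatter) and a 4.6-fold higher number from compound 1 to compound 4 (0.66 log units; beyond the scatter), all beyond the scatter. The carbon is therefore not indifferent to what it carries: the exchange of methyl (1 heavy atom) for trifluoromethyl (4 heavy atoms), with no hydrogen-bond donor, hydrogen-bond acceptor or net charge entering or leaving, is enough to raise the number in this assay, while the three earlier groups could not be told apart. Nothing available here accounts for the rise at this carbon.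

On these data alone, it remains open whether the higher number belongs to trifluoromethyl alone or extends to other groups at the same carbon, such as chloro, ethyl, methoxy or nitrile. Also open, as far as these compounds go, is whether the same exchange gives a step of similar size when the fluoro group on the ring is replaced by hydrogen or moved elsewhere on the ring.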